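Swapping Acetyl for Dimethylamino in a Pyrazole Series

The source may report more compounds than this note shows. Statements on the series, on what has been measured and on what is new or still open speak of the compounds shown alone.

Measured compounds:
- compound 1 `COc1cc(C)cc(-c2c(-c3ccnc(-c4ccc(C(C)=O)cc4)c3)cnn2CC#N)c1`: 84%
- compound 2 `Cc1cc(O)cc(-c2nn(CC#N)cc2-c2ccnc(-c3ccc(Oc4ccccc4)cc3)c2)c1`: 85%
- compound 3 `COc1cc(C)cc(-c2nn(CC#N)cc2-c2ccnc(-c3ccc(N(C)C)cc3)c2)c1`: 74%

Of the compounds shown here, three have been tested in a functional assay on MDA-MB-468 cells (Homo sapiens) for cytotoxicity, read by sulforhodamine B assay, with a stated time of 48 h, tested at 0.01 uM; on this read-out lower numbers stand for a stronger effect and higher numbers for a weaker effect at the one concentration tested. In this assay compound 1 gives 84%, the second highest of the three numbers. Compound 2 comes nearest and compound 3 is furthest; both of these gaps lie within the scatter of the method, so on the numbers shown the three compounds cannot be told apart.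

Compound 4 `COc1cc(C)cc(-c2c(-c3ccnc(-c4ccc(N(C)C)cc4)c3)cnn2CC#N)c1` has not yet been measured. It differs from compound 1 in one place: dimethylamino in place of acetyl on an aromatic carbon. Compound 3 also carries a dimethylamino group on its outer ring, but it differs from compound 4 elsewhere as well; in this assay compound 3 gives 74%, which is only a loose pointer, not a step.

Among the measured compounds shown here, with no step between measured compounds to lean on, the expectation for compound 4 is a small change in this assay, a step of a number 6 percentage points lower from compound 1 to compound 4 (within the scatter), towards a slightly stronger effect, but not beyond the scatter. Compound 4 is therefore expected to give 78%, with a likely range from 62% to 94%.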

Compound 4, a percentage reported as activity, at one concentration (the size of the read-out at that concentration, not a potency): -10%
Beside the measured number, compound 4's estimate is 88 percentage points above it; measured number below the stated range.
By their numbers in this assay, from the lowest: compound 4; then compounds 3, 1 and 2 (each within the scatter of the next, the first and the last beyond it).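

In this assay, among the compounds shown here, replacing acetyl with dimethylamino on an aromatic carbon, para to a large group, gives a number 94 percentage points lower from compound 1 to compound 4 (beyond the scatter), the first step in this set that can be read from a single change and one that lies far outside the usual variation between repeat measurements. The two groups match in much of what is counted: each has 3 heavy atoms, no ring, one hydrogen-bond acceptor, no hydrogen-bond donor and no net charge, yet acetyl has a double bond and oxygen where dimethylamino has nitrogen, so this place on the ring is highly sensitive to a change that leaves those counts untouched. Nothing shown here accounts for why this exchange has so large an effect.

From the compounds shown here alone, it remains open whether the effect belongs to dimethylamino itself or would also appear with another group at this place, such as a primary amine, a methoxy group, a diethylamino group with its longer chains or a carboxylic acid. With only one concentration tested, the result also leaves open how potency differs between the two compounds across a range of concentrations.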